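The compounds below may be only part of what the source reports. "The series", "measured", "known", "first", "only" and "open" are said of these compounds alone.

In a functional assay on MCF7 cells (Homo sapiens) for inhibition, read by MTT assay, with a stated time of 96 h (on this read-out lower numbers stand for stronger inhibition of growth and higher numbers for weaker inhibition of growth), three compounds have been measured:

Compound 1 `O=C(NCCCCCCSSCCCCCCNC(=O)c1cc(-c2ccncc2)n[nH]1)c1cc(-c2ccncc2)n[nH]1`: 7150 nM
Compound 2 `O=C(OCc1ccccc1)SCCCCCCNC(=O)c1cc(-c2ccncc2)n[nH]1`: 8370 nM
Compound 3 `O=C(NCCCCCCS)c1cc(C2CCCCC2)n[nH]1`: a limit only, > 50000 nM

Compound 2 holds the highest of the two numbers shown, and compound 1 sits within the usual scatter of it, so the two cannot be told apart. For compound 3 the assay gives no number, only the limit (the limit of > 50000 nM in this assay, at which 1 of the 3 values shown sits).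

Compound 4 `CCC(=O)SCCCCCCNC(=O)c1cc(-c2ccncc2)n[nH]1` differs from compound 2 in one place: ethyl in place of benzyloxy on a carbonyl carbon. Nothing measured here speaks to this change directly. The estimate is a step from compound 2 to compound 4 of a 1.4-fold higher number from compound 2 to compound 4 (0.16 log units; within the scatter), meaning weaker growth inhibition, but only modestly so. Compound 4 is expected at 12000 nM, between 4000 nM and 40000 nM.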

Compound 4, concentration for 50% growth inhibition: > 50000 nM
Compound 4 ended at the assay's limit; the forecaster's own chance of this, stated with the estimate: 15%; middle value at least 4.1-fold (0.61 log units) away from the limit.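

On the carbonyl carbon bound to sulfur, the group matters in this assay: ethyl in place of benzyloxy gives an at least 5.9-fold higher number from compound 2 to compound 4 (0.77 log units; beyond the scatter), a loss of growth inhibition. Within the data shown here, this is the first single change that can be read here, as the earlier compounds offered no pair differing in one place. Compound 4 gives only a limit, not a number, and joins compound 3 there: the limit of > 50000 nM in this assay, at which 2 of the 4 values shown sit.

Ethyl differs from benzyloxy by lacking both the aromatic ring and the oxygen, and the compounds shown do not tell which of these matters. A benzyl or an ethoxy group on the same carbonyl carbon would separate the two.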